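Swapping cyano for fluoro on compound 3

The source may report more compounds than this note shows. Statements on the series, on what has been measured and on what is new or still open speak of the compounds shown alone.

In a physicochemical assay for lipophilicity, read by HPLC (on this read-out lower numbers stand for lower lipophilicity and higher numbers for higher lipophilicity), compound 3 (`N#Cc1ccc(Cc2coc3ccccc3c2=O)cc1`) reads 3.58, which places it between compound 1 (`O=C1/C(=C/c2ccncc2)C(c2ccccc2)Oc2ccccc21`) at 2.98 and compound 2 (`O=C1/C(=C/c2ccccc2)C(c2ccccc2)Oc2ccccc21`) at 3.9. Compound 4 (`O=c1c(Cc2ccc(F)cc2)coc2ccccc12`) has not yet been measured. It carries fluoro in place of cyano on an aromatic carbon, para to a large group: fluoro in place of cyano on an aromatic carbon. Within the data shown here, only one measured step offers any guidance: a number 0.92 log units higher from compound 1 to compound 2 (beyond the scatter), where phenyl takes the place of pyridin-4-yl. That swap lies at another place on another core, so it is only a loose guide. A rise smaller than that step is therefore expected in this assay. The estimated change is a number 0.37 log units higher from compound 3 to compound 4 (beyond the scatter). Compound 4 is estimated at 3.95, with an expected range from 3.55 to 4.35.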

Compound 4, partition coefficient: 4.02
Compound 4: middle estimate off by 0.07 log units, on the low side; the range from low to high includes it.
By their numbers in this assay, from the lowest: compound 1; then compound 3; then compounds 2 and 4 (each within the scatter of the next).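

In this assay, fluoro in place of cyano on an aromatic carbon, para to a large group, gives a number 0.44 log units higher from compound 3 to compound 4 (beyond the scatter) on an otherwise unchanged structure. Among these compounds, this is the first step at this position, and it shows that the read-out responds to an exchange of this one small group, while the earlier step concerned a different place on a different core. Nothing measured here explains the rise.

As far as these compounds go, whether the same swap gives a similar step on another core remains open. So does the reading of an amine or a methoxy group on this aromatic carbon.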